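Replacing the aminoethyl chain in a succinimide series

A few compounds are considered here, and "the series" means these few. Any claim that something is new, unique, unknown or untested is made for them only; others in the source may bear on it.

Measured so far:
compound 1 `CCc1cnc(N2CCC(c3nc(COc4ccc(/C=C5\CC(=O)N(CCN)C5=O)cc4F)cs3)CC2)nc1` — "not determined" (no result reported) in a functional assay on cells for agonist activity at Glucose-dependent insulinotropic receptor (Homo sapiens), read by a luciferase reporter, with a stated time of 6 h; a lower number here means that less compound is needed, a higher number that more compound is needed for the effect
compound 2 `CCc1cnc(N2CCC(c3nc(COc4ccc(/C=C5\SC(=O)NC5=O)cc4F)cs3)CC2)nc1` — 780 nM
compound 3 `CCc1cnc(N2CCC(c3nc(COc4ccc(/C=C5\SC(=S)NC5=O)cc4F)cs3)CC2)nc1` — "not determined" (no result reported)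

Compound 1 stands without a single number in this assay, and the same holds for compound 3, so only compound 2 anchors the shared core with a value, which in this assay for compound 2 is 780 nM. Compound 4 `CCc1cnc(N2CCC(c3nc(COc4ccc(/C=C5\CC(=O)N(CC6CCOCC6)C5=O)cc4F)cs3)CC2)nc1` differs from compound 1 by oxan-4-yl in place of aminomethyl on a saturated chain carbon bound to an amide-type nitrogen in a ring. Among the compounds with values here, no step between two measured compounds is available to size this change; since compound 1 has no number, the estimate leans on compound 2 alone, and a step in either direction well beyond the usual scatter cannot be ruled out. Compound 4 is expected to give 800 nM, in the range 150 nM to 4000 nM.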

Compound 4, half-maximal effective concentration: 240 nM
Beside the measured number, compound 4's estimate is 3.3-fold (0.52 log units) above it, within the range that was stated.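

In this assay, within the data shown here, compound 4 gives 240 nM, but compound 1 has no single number, so no step between them can be read. The compounds shown leave open how 2-aminoethyl and (oxan-4-yl)methyl compare on the shared core. No evidence bears on this result.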